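Replacing methyl with 2-chlorophenyl on the piperazine nitrogen

This account rests on a few compounds, and the source may have more. Where it says the series, first, only, none or still open, it means among the compounds named here.

Of the compounds shown here, three sharing one core have been measured. Compound 1 `S=C(SCc1nc2cc(Cl)c(Cl)cc2[nH]1)N1CCOCC1` gives 5700 nM in a functional assay on MCF7 cells (Homo sapiens) for cytotoxicity, read by MTT assay, with a stated time of 24 h; on this read-out higher numbers stand for weaker inhibition and lower numbers for stronger inhibition. Compound 2 `CCOc1ccccc1N1CCN(C(=S)SCc2nc3cc(Cl)c(Cl)cc3[nH]2)CC1` gives 16200 nM in this assay. Compound 3 `CN1CCN(C(=S)SCc2nc3cc(Cl)c(Cl)cc3[nH]2)CC1` gives 30500 nM in this assay, the highest of the three numbers: a 5.4-fold higher number from compound 1 to compound 3 (0.73 log units; beyond the scatter) lies beyond the scatter, while a 1.9-fold higher number from compound 2 to compound 3 (0.27 log units; within the scatter) does not.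

Compound 4 `S=C(SCc1nc2cc(Cl)c(Cl)cc2[nH]1)N1CCN(c2ccccc2Cl)CC1` differs from compound 3 in one place: 2-chlorophenyl in place of methyl on an amine nitrogen in a ring.

For the measured compounds named here, the step that bears on this change is the one from compound 2 to compound 3, where a six-membered aromatic ring on that same ring nitrogen gave way to methyl and the number moved only within the scatter. Putting an aromatic ring back in place of methyl is therefore expected to move the number little, if anything toward the value of compound 2. The step of a 1.8-fold lower number from compound 3 to compound 4 (0.25 log units; within the scatter) is the estimated outcome. For compound 4 the estimate in this assay is 17000 nM, with a range from 7000 nM to 40000 nM.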

Compound 4, half-maximal inhibitory concentration: 60200 nM
For compound 4 the middle estimate is 3.5-fold (0.55 log units) below the measured one; measured number outside the range, above it.
By their numbers in this assay, from the lowest: compound 1; then compounds 2, 3 and 4 (each within the scatter of the next, the first and the last beyond it).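

In this assay, the three piperazine compounds no longer form a simple picture, since methyl and 2-chlorophenyl on the ring nitrogen cannot be told apart: a 2.0-fold higher number from compound 3 to compound 4 (0.30 log units; within the scatter). The aromatic ring's own substituent does register, however, with chloro in place of ethoxy on an aromatic carbon giving a 3.7-fold higher number from compound 2 to compound 4 (0.57 log units; beyond the scatter), so compound 3 lies within the scatter of both compound 2 and compound 4 while those two lie beyond it. No available measurement accounts for this difference.

The compounds shown leave open what an unsubstituted phenyl ring, or an amine or a carboxylic acid on that aromatic ring, would give in this assay. They also leave open whether any group on the piperazine nitrogen could bring the number close to that of compound 1, at 5700 nM.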